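Adding a Second Chloro Group to Compound 2

The compounds below may be only part of what the source reports. "The series", "measured", "known", "first", "only" and "open" are said of these compounds alone.

Measured so far:
compound 1 `ClCc1cccc(Cn2cnc3c(Cl)nc(Cl)nc32)c1`: 2950 nM
compound 2 `ClCc1ccccc1Cn1cnc2ncnc(Cl)c21`: 10200 nM
compound 3 `ClCc1cccc(Cn2cnc3nc(Cl)nc(Cl)c32)c1`: 260 nM

In a functional assay on DU-145 cells (Homo sapiens) for cytotoxicity, read by sulforhodamine B assay, with a stated time of 48 h (a lower number here means a stronger inhibitor of growth, a higher number a weaker inhibitor of growth), compound 2 gives 10200 nM, the highest of the three numbers. Compound 1 stands nearest to it, and compound 3 stands furthest, each with a lower number than compound 2, both gaps beyond the scatter. Compound 4 `ClCc1ccccc1Cn1cnc2nc(Cl)nc(Cl)c21` differs from compound 2 by chloro in place of hydrogen on an aromatic carbon. Among the compounds with values here, no measured pair shows this change by itself, so its size must be judged from the whole set. Compound 3, which also carries two chloro groups, gives 260 nM, a much lower number than compound 2, and compound 4 is expected to move in the same direction, by a step of about a 6.8-fold lower number from compound 2 to compound 4 (0.83 log units; beyond the scatter). Compound 4 is therefore estimated at 1500 nM, within a range from 300 nM to 7000 nM.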

Compound 4, concentration for total growth inhibition: 3230 nM
Compound 4: middle estimate off by 2.2-fold (0.33 log units), on the low side, within the range that was stated.
By their numbers in this assay, from the lowest: compound 3; then compounds 1 and 4 (each within the scatter of the next); then compound 2.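

In this assay, within the data shown here, chloro in place of hydrogen on an aromatic carbon between two ring nitrogen atoms gives a 3.2-fold lower number from compound 2 to compound 4 (0.50 log units; beyond the scatter) and this is the first pair in which that change stands alone. Among these compounds, it shows that this position accepts a second chloro group with a modest gain in growth inhibition, a size the earlier compounds could not show. Nothing measured here explains the step. On these data alone, whether an amine or a methoxy group in this place would do more or less stays open. So does whether the same step holds with the chloromethyl group placed as in compound 3.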